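A few compounds are considered here, and "the series" means these few. Any claim that something is new, unique, unknown or untested is made for them only; others in the source may bear on it.

Compound 2 `Cc1ccc(C2=NN(C3=NC(c4ccccc4)CS3)C(c3ccc4ccccc4c3)C2)cc1` is the starting point of this comparison. In a functional assay on HepG2 cells (Homo sapiens) for inhibition, read by CCK-8 assay, with a stated time of 48 h (a lower number here means a stronger inhibitor, a higher number a weaker inhibitor), compound 2 gives 14700 nM. Among the three compounds measured so far, compound 2 has the highest number; compound 3 `Cc1ccc(C2=NN(C3=NC(=O)CS3)C(c3ccc4ccccc4c3)C2)cc1` gives 12700 nM in this assay, and compound 1 `COc1ccc(C2=NN(C3=NC(c4ccccc4)CS3)C(c3cccc4ccccc34)C2)cc1` gives 8740 nM. All three numbers lie within the scatter of one another, so none of these compounds can be called stronger or weaker than the others.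

The change from compound 2 to compound 4 `COc1ccc(C2=NN(C3=NC(c4ccccc4)CS3)C(c3ccc4ccccc4c3)C2)cc1` is a small one: methoxy in place of methyl on an aromatic carbon. Among the compounds with values here, no measured pair shows exactly this change. Within the data shown here, the only single-point step available, a 1.2-fold lower number from compound 2 to compound 3 (0.06 log units; within the scatter), concerns a different part of the molecule and stayed within the scatter. Compound 1 also carries the methoxy group, but it differs from compound 2 in the naphthyl group as well, so its number can only be read alongside that of compound 2, and the two values sit within the scatter of each other.

With nothing in the data pointing either way, the expected step from compound 2 to compound 4 in this assay is a 1.3-fold lower number from compound 2 to compound 4 (0.13 log units; within the scatter), no change beyond the scatter. Compound 4 is therefore estimated at 11000 nM, with a range from 5000 nM to 25000 nM.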

Compound 4, half-maximal inhibitory concentration: 12600 nM
For compound 4 the middle estimate is 1.1-fold (0.06 log units) below the measured one; the range from low to high includes it.
By their numbers in this assay, from the lowest: compounds 1, 4, 3 and 2 (each within the scatter of the next).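

In this assay, within the data shown here, the step of a 1.2-fold lower number from compound 2 to compound 4 (0.07 log units; within the scatter) gives the first direct reading of 4-methylphenyl changing to 4-methoxyphenyl, and it shows that this swap, on an aromatic carbon para to a large group, brings in one hydrogen-bond acceptor without moving the number beyond the scatter. Compound 4 also provides a clean comparison of the two naphthyl attachments with the methoxy group held fixed: the step of a 1.4-fold higher number from compound 1 to compound 4 (0.16 log units; within the scatter) shows that naphthalen-2-yl in place of naphthalen-1-yl on a saturated ring carbon also stays within the scatter, so neither of these two single changes separates the compounds in this assay. No outside measurement is available to explain these results.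

The compounds shown leave open whether an amine, a carboxylic acid or a longer chain such as butoxy at this same aromatic carbon would shift the number beyond the scatter. They also leave open whether 4-methoxyphenyl would read the same alongside the smaller group on the ring nitrogen that compound 3 carries.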